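Moving a trifluoromethyl group on compound 2

The source may hold more compounds than are shown below. What is called first, only, known or untested is meant among the compounds shown, and "the series" means these compounds.

- compound 1 `COc1cc2ncnc(Nc3ccc(OC(F)(F)F)cc3)c2cc1OCCCCC(=O)Nc1ccc(S(N)(=O)=O)cc1` gives > 40000 nM
- compound 2 `NS(=O)(=O)c1ccc(NC(=S)Nc2ccc3ncnc(Nc4cccc(C(F)(F)F)c4)c3c2)cc1` gives 10100 nM

Among the compounds with values here, in a functional assay on A549 cells (Homo sapiens) for antiproliferative activity, read by MTT assay, with a stated time of 72 h (a lower number here means a stronger inhibitor, a higher number a weaker inhibitor), compound 2 at 10100 nM holds the only true number so far. Compound 1 stands at > 40000 nM and that is a limit of the assay, not a number. Compound 3 `NS(=O)(=O)c1ccc(NC(=S)Nc2ccc3ncnc(Nc4ccc(C(F)(F)F)cc4)c3c2)cc1` has the same atoms as compound 2, joined differently, and 4-(trifluoromethyl)phenyl in place of 3-(trifluoromethyl)phenyl on a nitrogen on an aromatic ring tells the change. Within the data shown here, no measured pair shows what such a change does, so the estimated 1.2-fold higher number from compound 2 to compound 3 (0.07 log units; within the scatter) stays within the usual scatter, in no firm direction. Compound 3 is expected at 12000 nM with 5000 nM to 30000 nM as its estimated range.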

Compound 3, half-maximal inhibitory concentration: > 40000 nM
Compound 3: only a limit was reported (the forecaster's own chance of this, stated with the estimate: 12%); at least 3.3-fold (0.52 log units) between middle value and limit.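

In this assay the swap of 3-(trifluoromethyl)phenyl for 4-(trifluoromethyl)phenyl gives an at least 3.9-fold higher number from compound 2 to compound 3 (0.59 log units; beyond the scatter) with no atom gained or lost, so this place on the nitrogen responds to how the same group is joined. Compound 3 at > 40000 nM stands at a limit of the assay and not a number. The step therefore gives only a minimum, and its true size cannot be read: the limit of > 40000 nM in this assay, at which 2 of the 3 values shown sit.

Still open, on these data alone, is what plain phenyl would give at this place. The same holds for a phenyl carrying an amine or a carboxylic acid instead of trifluoromethyl.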